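4-Fluorobenzyl in place of 3-chlorophenyl at a limit

A few compounds are considered here, and "the series" means these few. Any claim that something is new, unique, unknown or untested is made for them only; others in the source may bear on it.

Compound 1 (`COc1ccc2c(=O)c(/C=C/C(=O)Nc3cccc(C)c3)coc2c1`) gives > 200000 nM
Compound 2 (`COc1ccc2c(=O)c(/C=C/C(=O)Nc3cccc(Cl)c3)coc2c1`) gives > 200000 nM
Compound 3 (`COc1cccc(NC(=O)/C=C/c2coc3cc(OC)ccc3c2=O)c1`) gives > 200000 nM

All three results come from a functional assay on L02 cells (Homo sapiens) for inhibition, read by MTT assay, with a stated time of 48 h (on this read-out higher numbers stand for weaker inhibition and lower numbers for stronger inhibition), and all three are limits, not numbers. Compound 2 stands at > 200000 nM as a limit only. The whole set shows the same picture (the limit of > 200000 nM in this assay, at which 3 of the 3 values shown sit). The change to compound 4 (`COc1ccc2c(=O)c(/C=C/C(=O)NCc3ccc(F)cc3)coc2c1`) is 4-fluorobenzyl in place of 3-chlorophenyl on an amide-type nitrogen. The measured steps (a step that the two limits leave unreadable from compound 1 to compound 2 and a step that the two limits leave unreadable from compound 2 to compound 3) are swaps on an aromatic carbon, not on this nitrogen, and neither has a readable size. No step beyond the scatter is therefore expected in this assay, and no direction can be given. For compound 4 the estimated step is (a number no higher from compound 2 to compound 4 (the limit leaves the size open)). For compound 4 the estimated value is 200000 nM (expected range 100000 nM to 400000 nM).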

Compound 4, half-maximal inhibitory concentration: > 200000 nM
Compound 4: no number, only a limit; the forecaster's own chance of this, stated with the estimate: 80%; the middle value sits exactly at the limit.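

In this assay compound 4 gives > 200000 nM, a limit and not a number. Its steps from compound 1, compound 2 and compound 3 cannot be read. As far as these compounds go, what stays open is how the four compounds differ, if at all, in this assay.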